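This account rests on a few compounds, and the source may have more. Where it says the series, first, only, none or still open, it means among the compounds named here.

Compound 3 `O=c1[nH]cnc2c1c(-c1cccs1)cn2[C@@H]1O[C@H](CO)[C@@H](O)[C@H]1O` carries a thiophen-2-yl group on its core. In a functional assay on A549 cells (Homo sapiens), read by MTT assay, with a stated time of 72 h (a lower number here means a stronger inhibitor, a higher number a weaker inhibitor), compound 3 returns only a limit, > 20000 nM. Compound 2 `O=c1[nH]cnc2c1c(-c1ccoc1)cn2[C@@H]1O[C@H](CO)[C@@H](O)[C@H]1O`, with furan-3-yl in the same place, likewise gives a limit in this assay, > 20000 nM. The step that the two limits leave unreadable from compound 2 to compound 3 cannot be read, and the reason lies in the limit of > 20000 nM in this assay, at which 2 of the 3 values shown sit. Compound 1 `COc1ncnc2c1c(-c1ccsc1)cn2[C@@H]1O[C@H](CO)[C@@H](O)[C@H]1O`, whose core differs from the others, gives 5170 nM in this assay. Compound 4 `O=c1[nH]cnc2c1c(-c1ccsc1)cn2[C@@H]1O[C@H](CO)[C@@H](O)[C@H]1O` arises from compound 3 by thiophen-3-yl in place of thiophen-2-yl on an aromatic carbon. For the measured compounds named here, no measured step tests this swap on the shared core, so no shift beyond the scatter is expected, and a limit is again likely. Compound 4 is estimated at 25000 nM, with a range from 8000 nM to 80000 nM. The step that the limit leaves unreadable from compound 3 to compound 4 is thus expected to be small.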

Compound 4, half-maximal inhibitory concentration: > 20000 nM
Compound 4: a limit, no number; the forecaster's own chance of this, stated with the estimate: 70%; the middle value lies beyond the limit too.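

For the compounds shown here, no step among compound 2, compound 3 and compound 4 can be read, because all three share one limit: the limit of > 20000 nM in this assay, at which 3 of the 4 values shown sit.

The compounds shown leave open how strongly these three act in this assay and whether the thiophen-2-yl, thiophen-3-yl and furan-3-yl groups differ at all on the shared core.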